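Chain swaps at the amine of a shared core

The compounds below may be only part of what the source reports. "The series", "measured", "known", "first", "only" and "open" are said of these compounds alone.

Of the compounds shown here, two on a shared core have been tested in a functional assay on MCF7 cells (Homo sapiens) for cytotoxicity, read by MTT assay, with a stated time of 72 h; a lower number here means a stronger inhibitor of growth, a higher number a weaker inhibitor of growth. Compound 1 `CSc1nc(NCCCCc2ccccc2)c2ccccc2n1` carries a phenyl at the end of a longer saturated chain; in this assay compound 1 gives 32000 nM. Compound 2 `CSc1nc(NCc2ccccc2)c2ccccc2n1` carries the phenyl on a single saturated carbon bound to the ring nitrogen; in this assay compound 2 gives 41500 nM. The two numbers lie within the usual scatter of each other, so neither compound can be called the stronger one, and both sit at the weak end of what this kind of measurement covers.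

The next compound, compound 3 `CSc1nc(NCCCCCO)c2ccccc2n1`, differs from compound 2 in one place: 4-hydroxybutyl in place of phenyl on a saturated chain carbon bound to a nitrogen on an aromatic ring. Within the data shown here, no step between two measured compounds covers a change of this kind, so there is nothing in the measured pairs to calibrate it against.

With only two weak and mutually indistinguishable points, the expectation for compound 3 is a step of a 1.4-fold higher number from compound 2 to compound 3 (0.16 log units; within the scatter) toward a higher number, of a size that may not clear the scatter. Compound 3 is estimated at 60000 nM, with a range from 20000 nM to 200000 nM.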

Compound 3, concentration for 50% growth inhibition: 62000 nM
Compound 3: the middle estimate sits 1.0-fold (0.01 log units) below what was measured; the measured number falls inside the stated range.
By their numbers in this assay, from the lowest: compounds 1, 2 and 3 (each within the scatter of the next).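

In this assay, the change of phenyl to 4-hydroxybutyl on a saturated chain carbon bound to a nitrogen on an aromatic ring gives a 1.5-fold higher number from compound 2 to compound 3 (0.17 log units; within the scatter), so at this position a chain with no ring, carrying a hydrogen-bond donor and acceptor, cannot be told apart from phenyl. The second reading, hydroxymethyl in place of phenyl on a saturated chain carbon, four bonds along the chain from a nitrogen on an aromatic ring, gives a 1.9-fold higher number from compound 1 to compound 3 (0.29 log units; within the scatter), which is also within the scatter, so neither reading shows that the phenyl is needed for the weak growth inhibition seen across these three compounds. No supporting measurement is available to account for this flat reading.

Still open, as far as these compounds go, is whether an amine or a carboxylic acid at the end of the chain, or a longer chain ending in hydroxyl, would give a number clear of the scatter in this assay and away from the weak end of the measurement. The three compounds also share one core unchanged, so they say nothing on whether replacing the methylthio group would alter the reading.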